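The source may hold more compounds than are shown below. What is called first, only, known or untested is meant among the compounds shown, and "the series" means these compounds.

Working notes on the series. Of the compounds shown here, three have been measured in a functional assay on HeLa cells (Homo sapiens) for cytotoxicity, read by MTT assay, with a stated time of 72 h, tested at 30 uM; on this read-out higher numbers stand for more inhibition of growth at the one concentration tested and lower numbers for less inhibition of growth. Compound 1 `Cc1ccnc(/C(N)=N/NC(=S)N2CCN(c3ccccn3)CC2)c1` gives 77%. Compound 2 `Cc1cccc(/C(N)=N/NC(=S)N2CCCC2)n1` gives 74.5% in this assay. Compound 3 `N/C(=N\NC(=S)N1CCCC1)c1ccccn1` gives 84.5% in this assay. The difference between the core of compound 1 and the core of compound 2 is not broken down here. Compound 2 and compound 3 differ by hydrogen in place of methyl on an aromatic carbon, and the step is a number 10 percentage points higher from compound 2 to compound 3 (within the scatter).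

Compound 4 `N/C(=N\NC(=S)N1CCN(c2ccccn2)CC1)c1ccccn1` has not been measured. It differs from compound 1 by hydrogen in place of methyl on an aromatic carbon, which is the same kind of change as that from compound 2 to compound 3, though not the same: in compound 2 the methyl sits next to the ring nitrogen, whereas in compound 1 it sits opposite the ring nitrogen. Because compound 2 to compound 3 gave a number 10 percentage points higher from compound 2 to compound 3 (within the scatter), the expectation for compound 1 to compound 4 in this assay is a step of similar size, a number 5 percentage points higher from compound 1 to compound 4 (within the scatter), resting on that single precedent. Compound 4 is thus estimated at 82%, with a range from 68% to 93%.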

Compound 4, percent growth inhibition at one concentration: 78.9%
Compound 4: middle estimate off by 3.1 percentage points, on the high side; measured number inside the range.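

In this assay, hydrogen in place of methyl on the aromatic carbon opposite the ring nitrogen gives a step that reads a number 1.9 percentage points higher from compound 1 to compound 4 (within the scatter). Set beside the same kind of change on the other core, the two steps do not separate: the same change on two cores in this assay, a number 10 percentage points higher (within the scatter) from compound 2 to compound 3 and a number 1.9 percentage points higher (within the scatter) from compound 1 to compound 4, 8.1 percentage points apart, within the scatter of two such steps. Among these compounds, this shows that the series so far gives no sign that the core alters this step, but with both steps within the scatter it does not show that removing the methyl has any real effect, nor that a step of fixed size carries from one core to another, and the methyl of compound 2 also sits at another place on the ring than that of compound 1.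

Going by these compounds, whether a methoxy group, an amine or a carboxylic acid at this place on the ring would move the number beyond the scatter stays open. On these data alone, with only one concentration read in this assay, how these compounds compare at lower concentrations also stays open.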